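The compounds below may be only part of what the source reports. "The series", "measured", "known", "first", "only" and "open" are said of these compounds alone.

Compound 1, `CCCNC(=O)[C@@H]1C[C@H]2CCC[C@@H](C1)[C@@H]2NC(=O)c1cc2scnc2n1Cc1ccc(OC)cc1`: in an ADME assay on microsomes from liver (Homo sapiens) for metabolic stability (on this read-out higher numbers stand for a longer-lived compound and lower numbers for a shorter-lived compound), compound 1 gives 0.743 h.
Compound 2, `CCCNC(=O)[C@@H]1C[C@H]2CCC[C@@H](C1)[C@@H]2NC(=O)c1cc2sc(-c3ccccc3)nc2n1Cc1ccc(OC)cc1`: in this assay compound 2 gives 0.453 h.
Compound 3, `CCCNC(=O)C1CCN(C(=O)c2cc3sc(-c4ccccc4)cc3n2Cc2ccc(OC)cc2)CC1`: in this assay compound 3 gives 0.737 h.

Compound 2 and compound 1 share one core and differ in a single spot: hydrogen in place of phenyl on an aromatic carbon. That change made the step of a 1.6-fold higher number from compound 2 to compound 1 (0.21 log units; within the scatter). Compound 3 carries a different core; how its core differs from that of compound 2 is not broken down here, so only the two values can be set side by side.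

Compound 4, `CCCNC(=O)C1CCN(C(=O)c2cc3sccc3n2Cc2ccc(OC)cc2)CC1`, has not been measured yet. It comes from compound 3 by hydrogen in place of phenyl on an aromatic carbon. Among the measured compounds shown here, this is the same kind of change as the one from compound 2 to compound 1, not the same: in compound 2 the spot sits on a five-membered aromatic ring with 1 nitrogen and 1 sulfur, next to the ring nitrogen and next to the ring sulfur, while in compound 3 the ring holds 1 sulfur only and the spot is next to the ring sulfur.

Because the step of a 1.6-fold higher number from compound 2 to compound 1 (0.21 log units; within the scatter) stayed within the scatter, a step of about a 1.4-fold higher number from compound 3 to compound 4 (0.13 log units; within the scatter) is expected from compound 3 to compound 4 in this assay. Compound 4 is estimated at 1 h, between 0.5 h and 2 h.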

Compound 4, half-life: 0.177 h
Compound 4: middle estimate off by 5.6-fold (0.75 log units), on the high side; measured number outside the range, below it.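

In this assay, putting hydrogen in place of phenyl gave a 4.2-fold lower number from compound 3 to compound 4 (0.62 log units; beyond the scatter), so a lower number appeared on this core where the earlier step on the other core stayed within the scatter. The change therefore cannot be carried from one core to the other in this series as a fixed shift, since the two steps disagree: the same change on two cores in this assay, a 1.6-fold higher number (0.21 log units; within the scatter) from compound 2 to compound 1 and a 4.2-fold lower number (0.62 log units; beyond the scatter) from compound 3 to compound 4, 6.8-fold (0.83 log units) apart, beyond the scatter of two such steps. This pair of steps shows that the outcome of the change depends on the core, but it does not show which feature of the cores is responsible, as the core of compound 2 and the core of compound 3 differ in the ring that holds the spot and elsewhere too.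

The compounds shown leave open whether a small group at this spot, such as methyl or an amine, would behave more like phenyl or more like hydrogen. They also leave open how the change would behave on a third core, which could show whether either of the two steps is the more typical one.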